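The compounds below may be only part of what the source reports. "The series", "measured", "known", "first", "only" and "open" are said of these compounds alone.

Of the compounds shown here, three sharing one core have been measured in a functional assay on HCT-116 cells (Homo sapiens) for antiproliferative activity, read by CCK-8 assay, with a stated time of 72 h, tested at 2 uM; on this read-out higher numbers stand for a stronger effect at the one concentration tested and lower numbers for a weaker effect. Compound 1 `CN1CCN(c2nc(Cl)nc3c2ncn3Cc2ccc(C(=O)Nc3ccccc3N)cc2)CC1` gives 71.6%. Compound 2 `Nc1ccccc1NC(=O)c1ccc(Cn2cnc3c(Nc4cccc(OC(F)(F)F)c4)nc(Cl)nc32)cc1` gives 1.6%, and compound 3 `Nc1ccccc1NC(=O)/C=C/c1ccc(Cn2cnc3c(Nc4cccc(OC(F)(F)F)c4)nc(Cl)nc32)cc1` gives 2.8%. Compound 2 sits at the low end of the three numbers, with compound 3 within the scatter of it and compound 1 far above it. Going by the values given here, the step of a number 70 percentage points lower from compound 1 to compound 2 (beyond the scatter) is the one large change seen; the step of a number 1.2 percentage points higher from compound 2 to compound 3 (within the scatter) is within the scatter.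

Compound 4 `Nc1ccccc1NC(=O)c1ccc(Cn2cnc3c(Nc4cccc(Cl)c4)nc(Cl)nc32)cc1` differs from compound 2 by chloro in place of trifluoromethoxy on an aromatic carbon. Among the compounds with values here, no measured step touches this part of the molecule: the two recorded steps change either the group on the core or the linker to the amide, not the trifluoromethoxy, so they give no direct guide. With compound 2 at 1.6% and compound 3, which keeps the same aryl amine, at 2.8%, the expectation is that compound 4 also shows little effect, and the estimated step of a number 4.4 percentage points higher from compound 2 to compound 4 (within the scatter) is within the scatter. Compound 4 is therefore estimated at 6%, with a range from 0% to 25%.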

Compound 4, a percentage reported as inhibition, at one concentration (the size of the read-out at that concentration, not a potency): 56.2%
Beside the measured number, compound 4's estimate is 50.2 percentage points below it, and the stated range ends below it.
By their numbers in this assay, from the lowest: compounds 2 and 3 (each within the scatter of the next); then compound 4; then compound 1.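

Exchanging trifluoromethoxy for chloro on the aromatic ring, meta to a large group, produces a number 54.6 percentage points higher from compound 2 to compound 4 (beyond the scatter) in this assay and so shows that this single group can separate a nearly silent compound from a clearly active one. An aryl amine on the shared core therefore does not by itself remove the effect: (3-chlorophenyl)amino in place of 4-methylpiperazin-1-yl gives a number 15.4 percentage points lower from compound 1 to compound 4 (beyond the scatter) on this read-out. The same exchange with (3-(trifluoromethoxy)phenyl)amino gives the far larger a number 70 percentage points lower from compound 1 to compound 2 (beyond the scatter) by comparison. Nothing available here explains why the two groups differ so sharply.

Going by these compounds alone, how a fluoro, a methyl, a methoxy or an amine at this place would compare remains open, since only two groups appear there. Also open, as far as these compounds go, is whether the ethenyl-extended amide of compound 3 would keep its effect low when paired with chloro instead of trifluoromethoxy.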